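Shifting one fluorine on the benzyl group

The source may report more compounds than this note shows. Statements on the series, on what has been measured and on what is new or still open speak of the compounds shown alone.

Measured in a functional assay on U-251 cells (Homo sapiens) for antiproliferative activity, read by MTT assay, with a stated time of 24 h; on this read-out higher numbers stand for weaker inhibition and lower numbers for stronger inhibition:
compound 1 `C=CCOc1ccc2c(=O)c(-c3cc(OC)c(OC)cc3OC)coc2c1`: 5900 nM
compound 2 `COc1cc(OC)c(-c2coc3cc(OCc4ccccc4)ccc3c2=O)cc1OC`: 6750 nM
compound 3 `COc1cc(OC)c(-c2coc3cc(OCc4ccc(F)cc4)ccc3c2=O)cc1OC`: 3200 nM

Two steps fix where compound 3 stands: a 1.8-fold lower number from compound 1 to compound 3 (0.27 log units; within the scatter), which does not separate the pair, and a 2.1-fold lower number from compound 2 to compound 3 (0.32 log units; beyond the scatter), which does, though only modestly. Compound 4 `COc1cc(OC)c(-c2coc3cc(OCc4cccc(F)c4)ccc3c2=O)cc1OC` has the same atoms joined differently: 3-fluorophenyl in place of 4-fluorophenyl on a saturated chain carbon bound to an oxygen on an aromatic ring. In words, 3-fluorophenyl replaces 4-fluorophenyl. Going by the values given here, no measured pair moves a fluoro group, so there is no direct guide. The nearest evidence is that modest fluoro step, and a 1.1-fold higher number from compound 1 to compound 2 (0.06 log units; within the scatter) is also small. Little change is therefore expected in this assay. For compound 4, the estimated step is a 1.2-fold higher number from compound 3 to compound 4 (0.07 log units; within the scatter), expected to stay within the scatter. Compound 4 is estimated at 3800 nM, with an expected range of 1800 nM to 7500 nM.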

Compound 4, half-maximal inhibitory concentration: 3510 nM
The estimate for compound 4 lay 1.1-fold (0.03 log units) above the measured number; measured number inside the range.
By their numbers in this assay, from the lowest: compounds 3, 4, 1 and 2 (each within the scatter of the next, the first and the last beyond it).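

In this assay, the 3-fluorobenzyl group and the 4-fluorobenzyl group do not separate, with a 1.1-fold higher number from compound 3 to compound 4 (0.04 log units; within the scatter), so at this place the swap between these two fluorobenzyl groups registers as no real change. Adding fluoro to the plain benzyl group now gives a 1.9-fold lower number from compound 2 to compound 4 (0.28 log units; within the scatter), and 3-fluorophenyl in place of vinyl gives a 1.7-fold lower number from compound 1 to compound 4 (0.23 log units; within the scatter), so neither step clearly separates its pair. No evidence here explains these numbers. Going by these compounds, whether a larger group in place of the fluoro, such as methoxy or an amine, would move the number remains open.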